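Swapping Furan for Hydroxyphenyl on Two Dihydropyridine-Type Cores

This account rests on a few compounds, and the source may have more. Where it says the series, first, only, none or still open, it means among the compounds named here.

Compound 1 `CC1=C(C(=O)Nc2ccc(Cl)cc2)C(c2ccco2)C(C(=O)Nc2ccc(Cl)cc2)=C(C)N1` was examined in an ADME assay on Vero cells (Chlorocebus sabaeus) for cytotoxicity, read by sulforhodamine B assay, with a stated time of 3 days (on this read-out lower numbers stand for higher toxicity in this test and higher numbers for lower toxicity in this test), and gave 24 ug/mL. Compound 2 `CC1=C(C(=O)Nc2ccc(Cl)cc2)C(c2ccccc2O)C(C(=O)Nc2ccc(Cl)cc2)=C(C)N1` differs from it by one change (2-hydroxyphenyl in place of furan-2-yl on a saturated ring carbon); in this assay compound 2 gave 62 ug/mL, so that a 2.6-fold higher number from compound 1 to compound 2 (0.41 log units; beyond the scatter).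

Compound 3 `COc1ccc(NC(=O)C2=C(C)NC(=S)NC2c2ccco2)cc1` rests on a different core; how its core differs from that of compound 1 is not broken down here. In this assay compound 3 gave 230 ug/mL, the highest of the three numbers measured.

Compound 4 `COc1ccc(NC(=O)C2=C(C)NC(=S)NC2c2ccccc2O)cc1` has not yet been measured. It differs from compound 3 by 2-hydroxyphenyl in place of furan-2-yl on a saturated ring carbon. This is the same kind of change as that from compound 1 to compound 2, but its surroundings are not identical: in compound 3 the saturated ring carbon sits in a six-membered non-aromatic ring with 2 nitrogen, next to the ring nitrogen and next to the ring atom that bears a large group, whereas in compound 1 the ring holds 1 nitrogen and the carbon sits next to two ring atoms that each bear a (4-chlorophenyl)carbamoyl group.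

Because a 2.6-fold higher number from compound 1 to compound 2 (0.41 log units; beyond the scatter) was modest but beyond the scatter, a similar direction is expected here; the estimate is a 2.0-fold higher number from compound 3 to compound 4 (0.29 log units; within the scatter) for compound 4. Compound 4 is therefore expected to give about 450 ug/mL, most likely between 200 ug/mL and 1000 ug/mL.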

Compound 4, half-maximal cytotoxic concentration: 246 ug/mL
Beside the measured number, compound 4's estimate is 1.8-fold (0.26 log units) above it; the measured number falls inside the stated range.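

On the core of compound 3, placing 2-hydroxyphenyl where furan-2-yl stood on the saturated ring carbon gave, in this assay, a 1.1-fold higher number from compound 3 to compound 4 (0.03 log units; within the scatter). Set beside the earlier step, the result on this core cannot be told apart from the result on the core of compound 1: the same change on two cores in this assay, a 2.6-fold higher number (0.41 log units; beyond the scatter) from compound 1 to compound 2 and a 1.1-fold higher number (0.03 log units; within the scatter) from compound 3 to compound 4, 2.4-fold (0.38 log units) apart, within the scatter of two such steps. For the compounds shown here, this shows that on neither core did the change give a lower number beyond the scatter, but it does not show that the step carries over at a fixed size, as only one of the two steps lies beyond the scatter and two pairs establish no rule for the series.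

The compounds shown leave open whether other groups on that saturated ring carbon, such as an unsubstituted phenyl, a thiophene ring or a carboxylic acid, would fit the same picture. Also open, on these data alone, is how much the (4-chlorophenyl)carbamoyl groups and the methoxyphenyl amide each contribute, since these groups change only together with the core.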